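This account rests on a few compounds, and the source may have more. Where it says the series, first, only, none or still open, it means among the compounds named here.

Compound 1 `CCCCCCCCNc1nc(SCc2ccc(C(F)(F)F)cc2)nc2ccccc12` carries an octyl chain on a nitrogen on an aromatic ring of the shared core. In a functional assay on MDA-MB-231 cells (Homo sapiens) for cytotoxicity, read by MTT assay, with a stated time of 72 h (on this read-out higher numbers stand for weaker inhibition and lower numbers for stronger inhibition), compound 1 gives 22300 nM, the higher of the two numbers here, though its gap to compound 3 lies within the scatter. Compound 3 `FC(F)(F)c1ccc(CSc2nc(Nc3cccc(C(F)(F)F)c3)c3ccccc3n2)cc1` gives 11100 nM in this assay. Compound 2 `FC(F)(F)c1ccc(CSc2nc(Nc3ccccc3C(F)(F)F)c3ccccc3n2)cc1` reaches only a limit of this assay, > 50000 nM, so no number is known for it (the limit of > 50000 nM in this assay, at which 1 of the 3 values shown sits). The step of an at least 2.2-fold higher number from compound 1 to compound 2 (0.35 log units; beyond the scatter) and the step of a 2.0-fold lower number from compound 1 to compound 3 (0.30 log units; within the scatter) show that exchanging the octyl chain for an aryl group can move the number in either direction, and the step of an at least 4.5-fold lower number from compound 2 to compound 3 (0.65 log units; beyond the scatter) shows that which aryl group enters matters. Compound 4 `COc1ccc(Nc2nc(SCc3ccc(C(F)(F)F)cc3)nc3ccccc23)cc1OC` makes a change of the same kind: 3,4-dimethoxyphenyl in place of octyl on a nitrogen on an aromatic ring. A 3,4-dimethoxyphenyl group is another aryl group on that nitrogen, so a step of modest size either way is possible. For compound 4 the expected step is a 1.1-fold lower number from compound 1 to compound 4 (0.05 log units; within the scatter), close to no change beyond the scatter. The estimate for compound 4 is 20000 nM, with a range from 8000 nM to 50000 nM.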

Compound 4, half-maximal inhibitory concentration: 18900 nM
Compound 4: middle estimate off by 1.1-fold (0.02 log units), on the high side; low and high end bracket the measured number.
By their numbers in this assay, from the lowest: compounds 3, 4 and 1 (each within the scatter of the next). At a limit, above all of these: compound 2.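

Compound 4 puts an aromatic ring with two hydrogen-bond acceptors on this nitrogen in place of the octyl chain, yet the change stays small: a 1.2-fold lower number from compound 1 to compound 4 (0.07 log units; within the scatter). Among the aryl groups, a 1.7-fold higher number from compound 3 to compound 4 (0.23 log units; within the scatter), so 3,4-dimethoxyphenyl and 3-(trifluoromethyl)phenyl cannot be told apart here, whereas an at least 2.6-fold lower number from compound 2 to compound 4 (0.42 log units; beyond the scatter), which leaves 2-(trifluoromethyl)phenyl as the only group on this nitrogen that stands clearly apart from the others shown. That last step has no known upper end, because compound 2 sits at a limit of the assay: the limit of > 50000 nM in this assay, at which 1 of the 4 values shown sits.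

The compounds shown leave open whether a single methoxy group, as in 4-methoxyphenyl, would give a similar number to the two in compound 4. They also leave open whether a carboxylic acid or an amine on the aryl ring, or a shorter chain such as butyl, would move the number beyond the scatter.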